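Aryl group replaces cyclopropyl on the chain carbon

This account rests on a few compounds, and the source may have more. Where it says the series, first, only, none or still open, it means among the compounds named here.

Values in an ADME assay on A549 cells (Homo sapiens) for cytotoxicity, read by resazurin assay, with a stated time of 48 h (a lower number here means that less compound is tolerated, a higher number that more compound is tolerated), so far:
compound 1 `CC(C)Nc1ccc(NC(=O)c2cc(Cl)ccc2O)c(Cl)c1` gives 11000 nM
compound 2 `O=C(Nc1ccc(NCC2CC2)cc1Cl)c1cc(Cl)ccc1O` gives 14400 nM
compound 3 `CN(C)c1ccc(NC(=O)c2cc(Cl)ccc2O)c(Cl)c1` gives 85100 nM

Compound 2 stands second highest of the three numbers; its nearest neighbour is compound 1 (a 1.3-fold higher number from compound 1 to compound 2 (0.12 log units; within the scatter)), its furthest is compound 3 (a 5.9-fold higher number from compound 2 to compound 3 (0.77 log units; beyond the scatter)). Compound 4 `CN(C)c1ccc(CNc2ccc(NC(=O)c3cc(Cl)ccc3O)c(Cl)c2)cc1` is not yet measured; it differs from compound 2 by 4-(dimethylamino)phenyl in place of cyclopropyl on a saturated chain carbon bound to a nitrogen on an aromatic ring. Among the compounds with values here, no measured step touches this chain carbon. The steps that exist all alter the group on the ring nitrogen: a 1.3-fold higher number from compound 1 to compound 2 (0.12 log units; within the scatter) stays within the scatter, while a 7.7-fold higher number from compound 1 to compound 3 (0.89 log units; beyond the scatter) and a 5.9-fold higher number from compound 2 to compound 3 (0.77 log units; beyond the scatter) are modest. Nothing here tests an aromatic group at this place, so in this assay no step beyond the scatter is expected, with wide uncertainty. Compound 4 is expected to give 14000 nM, in a range of 5000 nM to 40000 nM, an expected step of a 1.0-fold lower number from compound 2 to compound 4 (0.01 log units; within the scatter).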

Compound 4, half-maximal cytotoxic concentration: 24500 nM
Beside the measured number, compound 4's estimate is 1.8-fold (0.24 log units) below it, within the range that was stated.
By their numbers in this assay, from the lowest: compounds 1, 2 and 4 (each within the scatter of the next, the first and the last beyond it); then compound 3.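

In this assay, within the data shown here, an aromatic group on this chain carbon is now tested for the first time: 4-(dimethylamino)phenyl in place of cyclopropyl gives a 1.7-fold higher number from compound 2 to compound 4 (0.23 log units; within the scatter) despite 9 heavy atoms entering where 3 leave. At this position, the exchange of a three-membered non-aromatic ring for a six-membered aromatic ring therefore does not move the number beyond the scatter. No supporting data explain this result.

Unsubstituted phenyl, and a phenyl bearing a carboxylic acid or a fluorine in place of dimethylamino, remain open. So does a pyridine ring on this chain carbon.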